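A few compounds are considered here, and "the series" means these few. Any claim that something is new, unique, unknown or untested is made for them only; others in the source may bear on it.

In an assay on cells for inhibition of protein deacetylase HDAC6 (Mus musculus), read by fluorescence, with a stated time of 30 min, tested at 100 uM (a higher number here means more inhibition at the concentration tested (going by the name of the read-out), a lower number less inhibition), compound 1 `COc1ccc(CN(CCN(C)C)c2ccc(C(=O)Nc3ccccc3N)cn2)cc1` gives 11%, compound 2 `COc1ccc(CN(CCN(C)C)c2ccc(C(=O)Nc3cc(Br)ccc3N)cn2)cc1` gives 21% and compound 3 `COc1ccc(CN(CCN(C)C)c2ccc(C(=O)Nc3cc(-c4ccccc4)ccc3N)cn2)cc1` gives 14%. Compound 2 has the highest of the three numbers, yet its gap to each of the others lies within the scatter: a number 10 percentage points higher from compound 1 to compound 2 (within the scatter) and a number 7 percentage points lower from compound 2 to compound 3 (within the scatter). Compound 4 `COc1ccc(CN(CCN(C)C)c2ccc(C(=O)Nc3cc(-c4ccco4)ccc3N)cn2)cc1` differs from compound 2 by furan-2-yl in place of bromo on an aromatic carbon. The step that bears most on this exchange is the one with phenyl in place of bromo, a number 7 percentage points lower from compound 2 to compound 3 (within the scatter), and a number 3 percentage points higher from compound 1 to compound 3 (within the scatter) shows that phenyl adds little over hydrogen. A step of similar size is therefore expected, with no change beyond the scatter, a number 5 percentage points lower from compound 2 to compound 4 (within the scatter). Compound 4 is expected to give 16%, within 5% to 30%.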

Compound 4, a percentage reported as inhibition, at one concentration (the size of the read-out at that concentration, not a potency): 15%
Compound 4: middle estimate off by 1 percentage points, on the high side; low and high end bracket the measured number.
By their numbers in this assay, from the lowest: compounds 1, 3, 4 and 2 (each within the scatter of the next).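

In this assay furan-2-yl at this carbon, para to an amino group, gives a number 6 percentage points lower from compound 2 to compound 4 (within the scatter) and a number 1 percentage points higher from compound 3 to compound 4 (within the scatter) and also a number 4 percentage points higher from compound 1 to compound 4 (within the scatter) so it stands level with bromo, phenyl and hydrogen. A five-membered aromatic ring with one hetero atom therefore joins the groups here that produce no step beyond the scatter. No measured evidence bears on this result and the numbers stand without explanation. Still open, on these data alone, is whether an aminomethyl group or a carboxylic acid at this carbon would move the number beyond the scatter.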